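Thiophen-2-yl in place of 4-nitrophenyl: working notes

This account rests on a few compounds, and the source may have more. Where it says the series, first, only, none or still open, it means among the compounds named here.

compound 1 `S=C(NCc1cccnc1)SCCc1noc(-c2ccccc2)n1` - 10100 nM
compound 2 `FC(F)(F)c1ccc(-c2nnc(CCSC(=S)NCc3cccnc3)o2)cc1` - 5490 nM
compound 3 `O=[N+]([O-])c1ccc(-c2nnc(CCSC(=S)NCc3cccnc3)o2)cc1` - 4600 nM

In a functional assay on MDA-MB-468 cells (Homo sapiens) for cytotoxicity, read by resazurin assay, with a stated time of 72 h (on this read-out lower numbers stand for stronger inhibition and higher numbers for weaker inhibition), compound 3 gives 4600 nM and sits at the low end of the three values. Its gap to compound 2 lies within the scatter, and only its gap to compound 1 goes beyond it. Compound 4 `S=C(NCc1cccnc1)SCCc1nnc(-c2cccs2)o1` carries thiophen-2-yl in place of 4-nitrophenyl on an aromatic carbon. Among the compounds with values here, only one measured step touches the group that leaves (a 1.2-fold lower number from compound 2 to compound 3 (0.08 log units; within the scatter)). Within the data shown here, that step stays within the scatter, and it exchanges a group on the aromatic ring, not the ring itself, so the data hold no direct precedent for this change. No step beyond the scatter is expected in this assay, although compound 1 (10100 nM) leaves room for a somewhat higher number. The estimated step is small (a 1.4-fold higher number from compound 3 to compound 4 (0.15 log units; within the scatter)). For compound 4 the expected value is 6500 nM (estimated range 2800 nM to 15000 nM).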

Compound 4, half-maximal inhibitory concentration: 3410 nM
For compound 4 the middle estimate is 1.9-fold (0.28 log units) above the measured one; measured number inside the range.
By their numbers in this assay, from the lowest: compounds 4, 3, 2 and 1 (each within the scatter of the next, the first and the last beyond it).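

In this assay the exchange of the whole aromatic ring gives a 1.3-fold lower number from compound 3 to compound 4 (0.13 log units; within the scatter) and so stays within the scatter, as does the exchange of a group on the ring, a 1.2-fold lower number from compound 2 to compound 3 (0.08 log units; within the scatter) in the earlier step. At this position, on the aromatic carbon of the five-membered ring with 2 nitrogen and 1 oxygen, a six-membered aromatic ring of carbon only with 9 heavy atoms in the group gives way to a five-membered aromatic ring with 5 heavy atoms, and the number does not leave the scatter. Nothing measured here accounts for this result.

All the groups shown at this position carry an aromatic ring, so a non-aromatic group such as cyclohexyl or a plain methyl there remains open. Also open, going by these compounds, is how an amine or a carboxylic acid on the thiophen-2-yl ring would read.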